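Methoxy removal on the pendant aryl ring

The source may report more compounds than this note shows. Statements on the series, on what has been measured and on what is new or still open speak of the compounds shown alone.

Among the compounds with values here, compound 1 `COc1ccc(-c2[nH]c3ccccc3c2/C=C(\C#N)S(=O)(=O)c2ccccc2)cc1` carries a methoxy on the aryl ring attached to the shared core and serves as the only anchor with a number: in a functional assay on RPMI-8226 cells (Homo sapiens) for inhibition, read by sulforhodamine B assay, with a stated time of 48 h (a higher number here means a weaker inhibitor of growth, a lower number a stronger inhibitor of growth), compound 1 gives 2100 nM. Compound 2 `COc1ccc2[nH]c(-c3ccccc3)c(/C=C(\C#N)S(=O)(=O)c3ccccc3)c2c1` places its methoxy instead on the fused ring system of the core; in this assay compound 2 gives "not determined" (no result reported), so compound 2 stands without a single number to compare against compound 1.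

Compound 3 `N#C/C(=C\c1c(-c2ccccc2)[nH]c2ccccc12)S(=O)(=O)c1ccccc1` is reached from compound 2 by hydrogen in place of methoxy on an aromatic carbon. Within the data shown here, no measured pair shows what dropping a methoxy does in this assay, and compound 2 itself offers no value to step from. The working expectation is that the change from compound 2 to compound 3 moves the concentration for half-maximal growth inhibition by no more than the usual scatter, in no clear direction, with compound 1 as the nearest measured relative of the bare scaffold.

On that basis compound 3 is estimated at 2500 nM, with a plausible range from 600 nM to 10000 nM.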

Compound 3, concentration for 50% growth inhibition: 714 nM
For compound 3 the middle estimate is 3.5-fold (0.54 log units) above the measured one; measured number inside the range.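

In this assay, within the data shown here, replacing methoxy with hydrogen on the aryl ring attached to the shared core gives a 2.9-fold lower number from compound 1 to compound 3 (0.47 log units; beyond the scatter) and is the first readable step; compound 3 is the stronger inhibitor of growth, so a methoxy on that ring is not required for activity in this pair. On these data alone, the corresponding step from compound 2 cannot be read, as compound 2 has no number, and the effect of a methoxy on the aromatic carbon meta to a fused ring and para to a fused ring remains unknown. Nothing at hand accounts for the step from compound 1.

As far as these compounds go, whether hydrogen is the best replacement on the aryl ring remains open, as a single step cannot rank it against fluorine, a hydroxyl or an amine at the same place. Also open, from the compounds shown here alone, is whether the step carries over when the nitrile gives way to a carboxylic acid, or when the phenyl ring on the sulfone gives way to a longer chain.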